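The source may hold more compounds than are shown below. What is called first, only, known or untested is meant among the compounds shown, and "the series" means these compounds.

Compound 1 `COc1ccc2nc(C)cc(NCc3ccc(F)cc3F)c2c1` gives 11600 nM in a functional assay on MCF-10A cells (Homo sapiens) for antiproliferative activity, with a stated time of 48 h; on this read-out lower numbers stand for an effect already at smaller amounts and higher numbers for an effect only at larger amounts of compound.
Compound 2 `COc1ccc2nc(C)cc(NCc3c(F)cccc3F)c2c1` gives 13600 nM in this assay.
Compound 3 `COc1ccc2nc(C)cc(NCc3ccc(F)cc3C(F)(F)F)c2c1` gives 5200 nM in this assay.

Among these three, compound 3 gives the lowest number, and its steps to the other two lie beyond the usual scatter. Compound 1 and compound 2 are built from the same atoms joined differently; the difference between the two cores is not broken down here, and their values in this assay lie within the scatter of each other, so no order between them is claimed.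

The step from compound 1 to compound 3 rests on one change, (trifluoromethyl in place of fluoro on an aromatic carbon), and it gave a 2.2-fold lower number from compound 1 to compound 3 (0.35 log units; beyond the scatter). Compound 4 `COc1ccc2nc(C)cc(NCc3c(F)cccc3C(F)(F)F)c2c1` has not yet been measured. Within the data shown here, it differs from compound 2 by trifluoromethyl in place of fluoro on an aromatic carbon, which is the same change at the same kind of place, so the earlier step is the only guide.

Beside that earlier step, compound 4 is expected to show a 2.2-fold lower number from compound 2 to compound 4 (0.34 log units; beyond the scatter). Among the measured compounds shown here, this expectation rests on the step of a 2.2-fold lower number from compound 1 to compound 3 (0.35 log units; beyond the scatter) and on nothing else, since only two such pairs exist here. Compound 4 is therefore estimated at 6200 nM, with a likely range from 3000 nM to 13000 nM.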

Compound 4, half-maximal effective concentration: 14200 nM
Compound 4: the middle estimate sits 2.3-fold (0.36 log units) below what was measured; measured number above the stated range.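

In this assay, trifluoromethyl in place of fluoro gave a 1.0-fold higher number from compound 2 to compound 4 (0.02 log units; within the scatter), so this step, unlike the earlier one on the core of compound 1, does not lie beyond the scatter. Even so, the two steps cannot be told apart when set side by side: the same change on two cores in this assay, a 2.2-fold lower number (0.35 log units; beyond the scatter) from compound 1 to compound 3 and a 1.0-fold higher number (0.02 log units; within the scatter) from compound 2 to compound 4, 2.3-fold (0.37 log units) apart, within the scatter of two such steps
Among these compounds, with only one pair on each core, this shows that the size of the earlier step cannot be relied on as a fixed amount to carry from one core to the other, but it does not show that the core truly alters the effect of the change, and it says nothing about any further core.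

The compounds shown leave open whether other groups in the same place, such as a chloro group, a nitrile or an amine, would follow either step. They also leave open how a carboxylic acid or a longer chain in place of the methyl group on the shared core would read in this assay.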